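Series notes: aryl replacement and kinase inhibition at one concentration

The compounds below may be only part of what the source reports. "The series", "measured", "known", "first", "only" and "open" are said of these compounds alone.

Measured compounds:
compound 1 `Cc1cc2nn(-c3ccccc3)c(N)c2c(=O)[nH]1`: -11%
compound 2 `Nc1c2c(=O)[nH]c(-c3ccccn3)cc2nn1-c1ccccc1`: 6%

In an assay on isolated protein for inhibition of ribosomal protein S6 kinase alpha-1 (Homo sapiens), read by mobility shift assay, tested at 30 uM (a lower number here means less inhibition, a higher number more inhibition at the concentration tested (going by the name of the read-out)), compound 1 gives -11% and compound 2 gives 6%. Among the measured compounds shown here, compound 2 stands higher of the two numbers: the only step, a number 17 percentage points higher from compound 1 to compound 2 (beyond the scatter), is the change of pyridin-2-yl in place of methyl on an aromatic carbon, and it lies beyond the scatter, though it remains a modest step on a weak read-out.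

Compound 3 `COc1ccc(-c2cc3nn(-c4ccccc4)c(N)c3c(=O)[nH]2)cc1` has not yet been measured in this assay. Relative to compound 2 it carries 4-methoxyphenyl in place of pyridin-2-yl on an aromatic carbon. For the measured compounds named here, no measured step exchanges one aryl group for another at this carbon; the single step at hand, a number 17 percentage points higher from compound 1 to compound 2 (beyond the scatter), shows that putting an aromatic ring on this carbon in place of methyl raised the number modestly. Compound 3 keeps an aromatic ring there, so the expectation is a number close to compound 2, with a number 2 percentage points higher from compound 2 to compound 3 (within the scatter) expected to fall within the scatter, direction uncertain. For compound 3 the estimated value is 8%, expected to lie between -10% and 30%.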

Compound 3, a percentage reported as inhibition, at one concentration (the size of the read-out at that concentration, not a potency): 4%
The estimate for compound 3 lay 4 percentage points above the measured number, within the range that was stated.
By their numbers in this assay, from the lowest: compound 1; then compounds 3 and 2 (each within the scatter of the next).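

In this assay, the exchange of pyridin-2-yl for 4-methoxyphenyl on this aromatic carbon gives a number 2 percentage points lower from compound 2 to compound 3 (within the scatter), so across this pair, neither the ring nitrogen of pyridin-2-yl nor the change to a carbon-only ring bearing methoxy registers in the read-out. Replacing methyl with 4-methoxyphenyl gives a number 15 percentage points higher from compound 1 to compound 3 (beyond the scatter), a second step from methyl to an aromatic ring that lies beyond the scatter, so the earlier step is no longer tied to pyridin-2-yl alone, although both steps stay modest and this holds only for these three compounds. The data offer nothing that explains either step.

As far as these compounds go, it remains open whether plain phenyl, or a phenyl ring carrying a carboxylic acid or an amine, would separate from these two aromatic groups at this carbon. Also open, from the compounds shown here alone, is whether a non-aromatic group such as a longer alkyl chain or a morpholine would stay close to methyl, and whether changes elsewhere on the shared core would move the number further.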